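Two Stereocentres Changed in a Compound Without Measured Cytotoxicity

A few compounds are considered here, and "the series" means these few. Any claim that something is new, unique, unknown or untested is made for them only; others in the source may bear on it.

Compound 1 `CC(C)C1=CC2=C(C(=O)C1=O)[C@]13CO[C@H]2C[C@H]1C(C)(C)C[C@H](O)C3` and compound 2 `CC(C)C1=C[C@@]23Oc4c(C(C)C)cc5c(c4O[C@]2(C(=O)C1=O)[C@]12CO[C@@H]3C[C@H]1C(C)(C)C[C@H](O)C2)[C@]12CO[C@@H]5C[C@H]1C(C)(C)C[C@H](O)C2` were both tested in a functional assay on HepG2 cells (Homo sapiens) for cytotoxicity, read by MTT assay; on this read-out higher numbers stand for weaker inhibition and lower numbers for stronger inhibition. Compound 1 reaches only a limit of the assay, > 10000 nM. In this assay compound 2 likewise reaches only a limit, > 10000 nM. Compound 2 therefore stands where the whole shown set stands, at the limit of > 10000 nM in this assay, at which 2 of the 2 values shown sit, and no number separates it from compound 1. Compound 3 `CC(C)C1=C[C@]23Oc4c(C(C)C)cc5c(c4O[C@@]2(C(=O)C1=O)[C@]12CO[C@@H]3C[C@H]1C(C)(C)C[C@H](O)C2)[C@]12CO[C@@H]5C[C@H]1C(C)(C)C[C@H](O)C2` has not yet been measured in this assay. Its relation to compound 2 is this: the two compounds have the same atoms and bonds and differ only in configuration as drawn: 2 of 10 stereo elements differ; a stereocentre at a saturated ring carbon is drawn S in compound 2 and R in compound 3; a stereocentre at a saturated ring carbon is drawn R in compound 2 and S in compound 3. For the measured compounds named here, no step between measured compounds is available, so no measured change of this kind sets a size for the expectation. Compound 3 is expected to show no step beyond the scatter, a step that the limit leaves unreadable from compound 2 to compound 3, and most probably to return only a limit again. The estimate for compound 3 in this assay is 15000 nM, with a range from 5000 nM to 50000 nM.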

Compound 3, half-maximal inhibitory concentration: 5200 nM
Compound 3: middle estimate off by 2.9-fold (0.46 log units), on the high side; the range from low to high includes it.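

In this assay, compound 3 is the only compound shown that returns a number rather than a limit, and the pair gives an at least 1.9-fold lower number from compound 2 to compound 3 (0.28 log units; that floor lies within the scatter). For the compounds shown here, this is the first sign that this change of configuration at two saturated ring carbons may be compatible with a measurable read-out, and any difference within this pair can only lie there: the fact that compounds 2 and 3 differ only in the configuration as drawn Compound 2 gives > 10000 nM, which is a limit of the assay, so the step has a lower bound but no known size, and it does not establish a real difference.

The compounds shown leave open whether either stereocentre alone would be enough, since the two differ together. They also leave open whether an amine or a carboxylic acid on the shared core would shift the value in this assay.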